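Aryl exchange on the carbonyl carbon of compound 1

A few compounds are considered here, and "the series" means these few. Any claim that something is new, unique, unknown or untested is made for them only; others in the source may bear on it.

Compound 1 `COc1cc(-c2cc(/C=C/C(=O)c3ccc(N)cc3)[nH]n2)cc(OC)c1OC` and compound 2 `COc1ccc(-c2cc(/C=C/C(=O)c3ccc(N)cc3)[nH]n2)cc1OC` share one core; the third member, compound 3 `COc1cc(-c2cc(/C=C/C(=O)c3ccc(F)c(F)c3)[nH]n2)cc(OC)c1OC`, is not yet measured. In a functional assay on LOX IMVI cells (Homo sapiens) for inhibition, read by sulforhodamine B assay, with a stated time of 48 h (on this read-out lower numbers stand for higher toxicity in this test and higher numbers for lower toxicity in this test), compound 1 gives 6720 nM, and compound 2 gives 7980 nM. For the measured compounds named here, compound 1 holds the lowest of these two numbers, but the only measured step, a 1.2-fold higher number from compound 1 to compound 2 (0.07 log units; within the scatter), lies within the scatter, so neither compound is set apart. Compound 3 differs from compound 1 by 3,4-difluorophenyl in place of 4-aminophenyl on a carbonyl carbon. Going by the values given here, no measured step touches the aryl on the carbonyl carbon; the single step recorded concerns hydrogen in place of methoxy on an aromatic carbon and was flat. The expectation therefore rests on the lack of any comparable step rather than on a precedent, and no step beyond the scatter is assumed, with a wide range in either direction. The estimate for compound 3 in this assay is 8000 nM, between 2500 nM and 25000 nM, which is expected to correspond to a 1.2-fold higher number from compound 1 to compound 3 (0.08 log units; within the scatter).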

Compound 3, concentration lethal to 50% of the cells: 41500 nM
Estimate against measurement, compound 3: 5.2-fold (0.71 log units) below, and the stated range ends below it.
By their numbers in this assay, from the lowest: compounds 1 and 2 (each within the scatter of the next); then compound 3.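

In this assay, for the compounds shown here, the aryl on the carbonyl carbon is the first place where a single change moves the number beyond the scatter (3,4-difluorophenyl in place of 4-aminophenyl: a 6.2-fold higher number from compound 1 to compound 3 (0.79 log units; beyond the scatter)). The earlier step concerned methoxy on an aromatic carbon and stayed within the scatter (a 1.2-fold higher number from compound 1 to compound 2 (0.07 log units; within the scatter)), whereas this position responds, and the change runs towards lower toxicity in this test. Going by these compounds alone, the exchange also drops the hydrogen-bond donor and acceptor counted for 4-aminophenyl, but no data tie the step to that difference or to any other feature of the two groups.

The compounds shown leave open whether losing the amine or adding the two fluorines carries the step, which unsubstituted phenyl or 4-fluorophenyl on the same carbonyl carbon would separate. As far as these compounds go, whether the step holds on the core of compound 2 also stays open.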